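Chloro in place of hydrogen on the benzyl ring

The source may report more compounds than this note shows. Statements on the series, on what has been measured and on what is new or still open speak of the compounds shown alone.

Measured compounds:
compound 1 `[O-][n+]1nc(NCc2ccccc2)[n+]([O-])c2ccccc21`: 8200 nM
compound 2 `O=[N+]([O-])c1ccc(CNc2n[n+]([O-])c3ccccc3[n+]2[O-])cc1`: 7700 nM
compound 3 `CCN(CC)c1n[n+]([O-])c2ccccc2[n+]1[O-]`: > 107000 nM (a limit)

In a functional assay on HepG2 cells (Homo sapiens) for cytotoxicity, read by MTT assay, with a stated time of 48 h (on this read-out lower numbers stand for stronger inhibition and higher numbers for weaker inhibition), compound 1 gives 8200 nM, the higher of the two numbers recorded. Its nearest neighbour is compound 2, which gives 7700 nM in this assay, and the step of a 1.1-fold lower number from compound 1 to compound 2 (0.03 log units; within the scatter) lies within the scatter. For compound 3 the result in this assay is a limit rather than a number, > 107000 nM, so that the limit of > 107000 nM in this assay, at which 1 of the 3 values shown sits, marks where one of the three values sits.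

Compound 4 `[O-][n+]1nc(NCc2ccccc2Cl)[n+]([O-])c2ccccc21` is not yet measured in this assay. It differs from compound 1 by chloro in place of hydrogen on an aromatic carbon. Going by the values given here, the only measured step that touches the same benzyl ring is a 1.1-fold lower number from compound 1 to compound 2 (0.03 log units; within the scatter), a change on an aromatic carbon of that ring that stayed within the scatter. On that basis no shift beyond the scatter is expected for compound 4 in this assay, and the expected step of a 1.1-fold lower number from compound 1 to compound 4 (0.04 log units; within the scatter) is accordingly small. The estimate for compound 4 in this assay is 7500 nM, with a range from 3000 nM to 19000 nM.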

Compound 4, half-maximal inhibitory concentration: 9700 nM
Compound 4: middle estimate off by 1.3-fold (0.11 log units), on the low side; the measured number falls inside the stated range.
By their numbers in this assay, from the lowest: compounds 2, 1 and 4 (each within the scatter of the next). At a limit, above all of these: compound 3.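

In this assay, chloro in place of hydrogen on an aromatic carbon of the benzyl ring, ortho to a large group, gives a 1.2-fold higher number from compound 1 to compound 4 (0.07 log units; within the scatter), so the two numbers cannot be told apart at this position. Going by these compounds alone, the only earlier step on this ring was the nitro change, a 1.1-fold lower number from compound 1 to compound 2 (0.03 log units; within the scatter); the new result adds a second substituent, a different group at a carbon ortho to a large group, and again the step stays within the scatter, so neither of the two substituents on this ring yet separates a compound from the unsubstituted benzyl parent. Nothing measured here speaks to why chloro at this carbon leaves the result indistinguishable from hydrogen.

As far as these compounds go, it remains open whether an amine, a carboxylic acid or a methoxy group on the same ring would give a step beyond the scatter in this assay. From the compounds shown here alone, compound 3 gives only a limit, > 107000 nM, and how a longer chain in place of the benzyl group would read stays open.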